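Trifluoromethyl in place of dimethylamino on compound 1

This account rests on a few compounds, and the source may have more. Where it says the series, first, only, none or still open, it means among the compounds named here.

In an ADME assay on J774.1 cells (Mus musculus) for cytotoxicity, read by MTT assay, with a stated time of 48 h (a higher number here means a weaker inhibitor, a lower number a stronger inhibitor), compound 1 `Cc1c(C(=O)N/N=C/c2ccc(N(C)C)cc2)no[n+]1[O-]` gives 129000 nM and compound 2 `O=C(N/N=C/c1ccc2nonc2c1)c1cccnc1` gives 209000 nM while compound 3 `Cc1c(C(=O)N/N=C/c2ccc([N+](=O)[O-])o2)no[n+]1[O-]` gives 68000 nM under the same conditions. Compound 1 thus lies within the usual scatter of both others. Compound 4 `Cc1c(C(=O)N/N=C/c2ccc(C(F)(F)F)cc2)no[n+]1[O-]` has not been measured yet. It carries trifluoromethyl in place of dimethylamino on an aromatic carbon and otherwise keeps the core of compound 1. Among the measured compounds shown here, no measured pair differs in one place only, so the data do not show the size of such a swap. Starting from compound 1 at 129000 nM only a modest shift is expected in this assay and none beyond the scatter. The expected change is a 1.3-fold lower number from compound 1 to compound 4 (0.11 log units; within the scatter) and stays within the scatter. Compound 4 is estimated at 100000 nM (range 40000 nM to 250000 nM).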

Compound 4, half-maximal inhibitory concentration: > 400000 nM
Compound 4 ended at the assay's limit (the forecaster's own chance of this, stated with the estimate: 10%); middle value at least 4.0-fold (0.60 log units) away from the limit.
By their numbers in this assay, from the lowest: compounds 3, 1 and 2 (each within the scatter of the next, the first and the last beyond it). At a limit, above all of these: compound 4.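

Trifluoromethyl in place of dimethylamino on this aromatic carbon gives an at least 3.1-fold higher number from compound 1 to compound 4 (0.49 log units; beyond the scatter) in this assay. Among the compounds shown here, this is the first single change that can be sized here, and it shows that cytotoxicity readings can depend on the group at this position. Its full size stays unknown, since compound 4 sits at a limit of the assay rather than at a true number: the limit of > 400000 nM in this assay, at which 1 of the 4 values shown sits.

Going by these compounds, whether losing dimethylamino or gaining trifluoromethyl drives the step remains open. A methoxy group, a primary amine or a carboxylic acid at this position would help separate the two.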